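The compounds below may be only part of what the source reports. "The series", "measured", "known", "first", "only" and "open" are said of these compounds alone.

In a functional assay on A549 cells (Homo sapiens) for antiproliferative activity, read by MTT assay, with a stated time of 48 h (a lower number here means a stronger inhibitor, a higher number a weaker inhibitor), three compounds have been measured:

Compound 1 `COc1ccc(-c2cn3cc(C4=CCN(C(=O)c5cccc(C(F)(F)F)c5)CC4)ccc3n2)cc1OC` gives 3690 nM
Compound 2 `COc1ccc(-c2cn3cc(C4=CCN(S(=O)(=O)c5ccccc5)CC4)ccc3n2)cc1OC` gives 7660 nM
Compound 3 `COc1ccc(-c2cn3cc(C4=CCN(S(=O)(=O)C5CCCC5)CC4)ccc3n2)cc1OC` gives 6470 nM

On these numbers compound 3 holds the second highest of the three, but the steps of a 1.2-fold lower number from compound 2 to compound 3 (0.07 log units; within the scatter) and a 1.8-fold higher number from compound 1 to compound 3 (0.24 log units; within the scatter) both lie within the usual scatter of repeated measurements, so compound 3 cannot be told apart from either neighbour. Going by the values given here, only the step of a 2.1-fold higher number from compound 1 to compound 2 (0.32 log units; beyond the scatter) reaches beyond the scatter.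

Compound 4 `COc1ccc(-c2cn3cc(C4=CCN(S(=O)(=O)CCc5ccccc5)CC4)ccc3n2)cc1OC` is made from compound 3 by a single change: phenethyl in place of cyclopentyl on a sulfonyl sulfur. Among the compounds with values here, the one measured step that bears on this place is a 1.2-fold lower number from compound 2 to compound 3 (0.07 log units; within the scatter), where exchanging the group on the sulfonyl sulfur moved the number only within the scatter. With a single such precedent, a change at the same place is expected to give a 1.0-fold higher number from compound 3 to compound 4 (0.00 log units; within the scatter), that is, nothing beyond the scatter. Compound 4 is therefore estimated at 6500 nM, with a range from 3200 nM to 13000 nM.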

Compound 4, half-maximal inhibitory concentration: 7690 nM
Estimate against measurement, compound 4: 1.2-fold (0.07 log units) below; measured number inside the range.
By their numbers in this assay, from the lowest: compounds 1, 3, 2 and 4 (each within the scatter of the next, the first and the last beyond it).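

On the sulfonyl sulfur, phenethyl now joins phenyl and cyclopentyl as a third group that cannot be told apart from the others in this assay: both a 1.2-fold higher number from compound 3 to compound 4 (0.08 log units; within the scatter) and a 1.0-fold higher number from compound 2 to compound 4 (0.00 log units; within the scatter) stay within the scatter, even though phenethyl has 8 heavy atoms against 5 for cyclopentyl and carries its aromatic ring on a chain. Exchanging the whole group on the ring nitrogen gives a less even picture, as a 2.1-fold higher number from compound 1 to compound 4 (0.32 log units; beyond the scatter) lies beyond the scatter, but only modestly, and a 1.8-fold higher number from compound 1 to compound 3 (0.24 log units; within the scatter) does not, so compound 1 is not cleanly separated from the sulfonyl compounds as a set. Nothing measured here gives a reason for these numbers.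

Still open, from the compounds shown here alone, is whether an amine, a carboxylic acid or a longer chain on the sulfonyl sulfur would also stay within the scatter. Also open, going by these compounds, is whether a plain phenylcarbonyl group, without the trifluoromethyl, would differ from its phenylsulfonyl partner, compound 2.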